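Swapping the Amide Substituent of Compound 2

The source may report more compounds than this note shows. Statements on the series, on what has been measured and on what is new or still open speak of the compounds shown alone.

Measured compounds:
compound 1, `CCOc1ccc2cc(C(=O)NCCO)c(=O)oc2c1`
compound 2, `CCN(CC)c1ccc2cc(C(=O)NCCO)c(=O)oc2c1`

In a functional assay on HeLa cells (Homo sapiens) for cytotoxicity, read by MTT assay, with a stated time of 72 h (on this read-out higher numbers stand for weaker inhibition and lower numbers for stronger inhibition), compound 1 gives > 100000 nM, which is a limit of the assay rather than a number. In this assay compound 2 gives > 100000 nM, again only a limit. Both readings sit at the limit of > 100000 nM in this assay, at which 2 of the 2 values shown sit, so the step that the two limits leave unreadable from compound 1 to compound 2 cannot be read. Compound 2 therefore stands only at a limit on the numbers shown.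

Compound 3 `CCN(CC)c1ccc2cc(C(=O)NC(C)C)c(=O)oc2c1` differs from compound 2 by isopropyl in place of 2-hydroxyethyl on an amide-type nitrogen. For the measured compounds named here, no measured step bears on this change. The expected step of a number no higher from compound 2 to compound 3 (the limit leaves the size open) is therefore none beyond the scatter. Compound 3 is estimated at 100000 nM, in the range 30000 nM to 300000 nM, most likely again reported as a limit.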

Compound 3, half-maximal inhibitory concentration: 73000 nM
Estimate against measurement, compound 3: 1.4-fold (0.14 log units) above; the measured number falls inside the stated range.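

In this assay, isopropyl in place of 2-hydroxyethyl on an amide-type nitrogen gives an at least 1.3-fold lower number from compound 2 to compound 3 (0.13 log units; that floor lies within the scatter). For the compounds shown here, this makes compound 3 the first compound here with a measured number rather than a limit, so a change at this position can bring the reading within the range the assay can measure. Going by these compounds, the full size of the step remains unknown, and its floor alone does not show a change beyond the scatter.

On these data alone, whether a longer chain or an amine on this nitrogen would lower the number further remains open. So does whether isopropyl would give a measurable number with ethoxy on the shared core, as in compound 1.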